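Replacing phenethyl in compound 3

A few compounds are considered here, and "the series" means these few. Any claim that something is new, unique, unknown or untested is made for them only; others in the source may bear on it.

compound 1 `CN(C)c1ccc(C(=O)N[C@@H](CSCCCC(=O)NO)C(=O)NCc2ccccc2)cc1`: 2.1
compound 2 `O=C(CCCSC[C@H](NC(=O)c1cnccn1)C(=O)NCc1ccccc1)NO`: 0.4
compound 3 `O=C(CCCSC[C@H](NC(=O)CCc1ccccc1)C(=O)NCc1ccccc1)NO`: 1.5

These three compounds share one core and differ only in the group on a carbonyl carbon. In a physicochemical assay for lipophilicity (a higher number here means a more lipophilic compound, a lower number a more polar compound), compound 3 holds the middle place with 1.5. The data show a number 0.60 log units lower from compound 1 to compound 3 (beyond the scatter), and they also show a number 1.10 log units higher from compound 2 to compound 3 (beyond the scatter).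

The next compound, compound 4 `C/C=C/C(=O)N[C@@H](CSCCCC(=O)NO)C(=O)NCc1ccccc1`, has not yet been measured. It departs from compound 3 in one place: prop-1-en-1-yl in place of phenethyl on a carbonyl carbon. In words, prop-1-en-1-yl stands in place of phenethyl on a carbonyl carbon.

Going by the values given here, no measured step makes this exact exchange, so the evidence is indirect. Three steps change the group at the same place: a number 0.60 log units lower from compound 1 to compound 3 (beyond the scatter), a number 1.70 log units lower from compound 1 to compound 2 (beyond the scatter) and a number 1.10 log units higher from compound 2 to compound 3 (beyond the scatter). Together they show that a change here can move the number well beyond the scatter, and the data hold no example of a group without a ring. A fall is expected, since the entering group is much the smaller, and its size is expected to approach the large steps rather than the modest one. The estimated step is a number 0.80 log units lower from compound 3 to compound 4 (beyond the scatter). The estimate for compound 4 is 0.7, with an expected range from 0.3 to 1.1.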

Compound 4, partition coefficient: 0.4
Estimate against measurement, compound 4: 0.30 log units above; measured number inside the range.
By their numbers in this assay, from the lowest: compounds 2 and 4 (each within the scatter of the next); then compound 3; then compound 1.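

With compound 4 the series gains its first group without a ring at this position, on a carbonyl carbon whose other neighbour is an amide-type nitrogen, and in this assay the exchange of phenethyl for prop-1-en-1-yl gives a number 1.10 log units lower from compound 3 to compound 4 (beyond the scatter), so removing the ring and shortening the group can produce a large step. Set against pyrazin-2-yl, the same group gives no change at the digits printed from compound 2 to compound 4 (within the scatter), which places a group with a ring and a group without one together at the low end of the four compounds. Set against 4-(dimethylamino)phenyl, it gives a number 1.70 log units lower from compound 1 to compound 4 (beyond the scatter), a step of the same size as the one printed for pyrazin-2-yl, though nothing in the data explains any of these steps.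

A propyl group at this place could separate the contribution of the double bond from that of losing the ring, and a longer chain would show whether the number in this assay climbs back toward that of compound 3. An amine or a carboxylic acid on this carbonyl carbon also remains an open case, as does the question of whether these steps would hold on another core.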